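The source may hold more compounds than are shown below. What is called first, only, known or untested is meant among the compounds shown, and "the series" means these compounds.

Of the compounds shown here, two have been measured so far. Compound 1 `Nc1nc(O)c2c(n1)n(C1OC(CO)[C@@H](O)[C@H]1O)c(=O)n2C/C=C/c1ccccc1` and compound 2 `Cn1c(=O)n2c3c1c(=O)nc(N)n3CC1OC2[C@H](O)[C@@H]1O` were both tested in a functional assay on the whole organism with Mus musculus as the target; on this read-out higher numbers stand for larger maximal responses and lower numbers for smaller maximal responses. In this assay compound 1 gives 5%. In this assay compound 2 gives 0%. Compound 1 is placed at the top of the two numbers, but the gap to compound 2 lies within the scatter, so the two cannot be told apart; both sit close to no response at all.

The step followed here leads to compound 3 `CCCCCCn1c(=O)n(C2OC(CO)[C@@H](O)[C@H]2O)c2nc(N)nc(O)c21`, which has not yet been measured. The change from compound 1 is pentyl in place of 2-phenylethenyl on a saturated chain carbon bound to an aromatic nitrogen. For the measured compounds named here, no pair of measured compounds shows what such a change does to the response, so the expectation rests on the measured values alone. Compound 1, with its 5%, leaves little room for a smaller response, and nothing in the data points to a larger one. The expected step is no change at the digits printed from compound 1 to compound 3 (within the scatter), none beyond the scatter. For compound 3 the estimate in this assay is 5%, with a range from 0% to 15%.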

Compound 3, largest response reached (reported as maximal response), in percent of the reference or control that the assay uses: 11%
Estimate against measurement, compound 3: 6 percentage points below; measured number inside the range.
By their numbers in this assay, from the lowest: compounds 2, 1 and 3 (each within the scatter of the next, the first and the last beyond it).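

In this assay pentyl in place of 2-phenylethenyl gives a number 6 percentage points higher from compound 1 to compound 3 (within the scatter) and so cannot be told apart from no change at all. For the compounds shown here, this is the first step read at this place, on a saturated chain carbon bound to an aromatic nitrogen, and it shows that the six-membered aromatic ring of carbon only and the double bond outside aromatic rings can both leave, with the group going from 8 heavy atoms to 5, without the response moving beyond the scatter. Nothing measured on these compounds offers an explanation for this result.

A single step inside the scatter does not tell whether the group at this place has any bearing on the response, since the compounds in this step stay within the scatter of each other. Going by these compounds, it remains open whether a primary amine, a carboxylic acid or a chain longer than pentyl at the same place would lift the response clear of the scatter, or whether the response stays this small with any group there.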